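Removing the Hydroxyphenyl Arm from a Hydroxamic Acid

This account rests on a few compounds, and the source may have more. Where it says the series, first, only, none or still open, it means among the compounds named here.

Compound 1 `O=C(NO)c1cccc(/C=C/c2ccnc(-c3cc(F)ccc3O)c2)c1` and compound 2 `O=C(NO)c1ccc(/C=C/c2ccnc(-c3cccc(O)c3)c2)cc1` share a core in which a hydroxamic acid is joined through a double bond to a ring bearing an aryl group. In a functional assay on MGC-803 cells (Homo sapiens) for antiproliferative activity, read by CellTiter-Glo, with a stated time of 72 h (on this read-out higher numbers stand for weaker inhibition and lower numbers for stronger inhibition), compound 1 gives 2710 nM and compound 2 gives 2100 nM. Compound 2 has the lower of the two numbers, but compound 1 lies within the usual scatter of it, so neither can be called stronger. Compound 3 `O=C(NO)c1ccc(/C=C/c2ccncc2)cc1` carries hydrogen in place of 3-hydroxyphenyl on an aromatic carbon. Within the data shown here, no measured pair shows this change, so its size is unknown; losing a whole ring is expected to move the number toward weaker inhibition, beyond the scatter. The expected step is a 3.1-fold higher number from compound 2 to compound 3 (0.49 log units; beyond the scatter). Compound 3 is therefore estimated at 6500 nM, within 2200 nM to 20000 nM.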

Compound 3, half-maximal inhibitory concentration: 3930 nM
The estimate for compound 3 lay 1.7-fold (0.22 log units) above the measured number; low and high end bracket the measured number.
By their numbers in this assay, from the lowest: compounds 2, 1 and 3 (each within the scatter of the next).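

Putting hydrogen in place of the 3-hydroxyphenyl, on the aromatic carbon next to the ring nitrogen, gives a 1.9-fold higher number from compound 2 to compound 3 (0.27 log units; within the scatter) in this assay. The whole arm can therefore go from this position without a shift that stands clear of the scatter on this read-out. Nothing at hand explains this result.

Going by these compounds, whether an amine, a methyl group or a plain phenyl ring at this position would give a number clearly apart from these stays open. So does whether the same removal would behave alike on the core of compound 1.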